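The source may report more compounds than this note shows. Statements on the series, on what has been measured and on what is new or still open speak of the compounds shown alone.

Measured in a physicochemical assay for solubility, read by spectrophotometry, in phosphate buffer, with a stated time of 2 h, at pH 7.4; a higher number here means a more soluble compound, a lower number a less soluble compound:
- compound 1 `COc1ccc2[nH]c(C(=O)N3CC(=O)N(Cc4ccccc4)[C@@H](CCc4ccccc4)C3)cc2c1` gives 4400 nM
- compound 2 `COc1ccc2[nH]c(C(=O)N3CC(=O)N(Cc4ccccc4)[C@@H](CN4CCCCC4)C3)cc2c1` gives > 25000 nM, a limit of the assay
- compound 3 `COc1ccc2[nH]c(C(=O)N3CC(=O)N(Cc4ccccc4)[C@@H](COCc4ccccc4)C3)cc2c1` gives 8800 nM

The two actual numbers are not separated, a 2.0-fold higher number from compound 1 to compound 3 (0.30 log units; within the scatter), so compound 3 stands level with compound 1.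

Compound 4 `COc1ccc2[nH]c(C(=O)N3CC(=O)N(Cc4ccccc4)[C@@H](CN4CCC(OC)CC4)C3)cc2c1` has 4-methoxypiperidin-1-yl in place of benzyloxy on a saturated chain carbon bound to a saturated ring carbon.

The closest measured step is an at least 2.8-fold lower number from compound 2 to compound 3 (0.45 log units; beyond the scatter), here read in reverse. an at least 5.6-fold higher number from compound 1 to compound 2 (0.75 log units; beyond the scatter) runs the same way. Within the data shown here, no measured step covers the methoxy group. A rise beyond the scatter is therefore expected, possibly reaching (the limit of > 25000 nM in this assay, at which 1 of the 3 values shown sits). The expected step is a 2.7-fold higher number from compound 3 to compound 4 (0.44 log units; beyond the scatter). Compound 4 is estimated at 24000 nM, with an expected range of 11000 nM to 32000 nM.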

Compound 4, solubility: > 25000 nM
Compound 4 ended at the assay's limit (the forecaster's own chance of this, stated with the estimate: 60%); at least 1.0-fold (0.01 log units) between middle value and limit.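

In this assay, 4-methoxypiperidin-1-yl in place of benzyloxy gives an at least 2.8-fold higher number from compound 3 to compound 4 (0.45 log units; beyond the scatter), and in place of benzyl it gives an at least 5.6-fold higher number from compound 1 to compound 4 (0.75 log units; beyond the scatter). On this saturated chain carbon bound to a saturated ring carbon, a second piperidine group thus stands clear of compound 1 and compound 3, so the result no longer rests on compound 2 alone. The step from compound 2 to compound 4 cannot be read, with both values being limits: the limit of > 25000 nM in this assay, at which 2 of the 4 values shown sit.

From the compounds shown here alone, how far compound 2 and compound 4 lie past that limit remains open. Also open, going by these compounds, is whether morpholin-4-yl or an open-chain dimethylamino group at this place would reach it too.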